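The source may hold more compounds than are shown below. What is called first, only, known or untested is meant among the compounds shown, and "the series" means these compounds.

Compound 1, `CC1(OC(=O)N2CCC(O[C@H]3CC[C@H](Oc4cnc(S(C)(=O)=O)cn4)CC3)CC2)CC1`, and compound 2, `CS(=O)(=O)c1cnc(O[C@H]2CC[C@H](OC3CCN(CC4(C(F)(F)F)CC4)CC3)CC2)cn1`, share one core and differ only in the group carried on the amine nitrogen in the ring. In a functional assay on isolated protein for agonist activity at Glucose-dependent insulinotropic receptor (Rattus norvegicus), read by HTRF and cAMP accumulation (a lower number here means a smaller maximal response, a higher number a larger maximal response), compound 1 gives 123%, and compound 2 gives 124%. The change between them moved the number a number 1 percentage points higher from compound 1 to compound 2 (within the scatter), so the two values cannot be told apart, and compound 2 stands level with compound 1 rather than ahead of it.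

Compound 3, `CS(=O)(=O)c1cnc(O[C@H]2CC[C@H](OC3CCN(CC4(C(F)(F)F)CCC4)CC3)CC2)cn1`, has not yet been measured in this assay. The difference from compound 2 is 1-(trifluoromethyl)cyclobutyl in place of 1-(trifluoromethyl)cyclopropyl on a saturated chain carbon bound to an amine nitrogen in a ring. Among the measured compounds shown here, the only measured step that bears on this place is the one from compound 1 to compound 2, which swapped the whole group at that nitrogen and still gave a number 1 percentage points higher from compound 1 to compound 2 (within the scatter). A change that only enlarges the ring inside that group, while keeping the trifluoromethyl and the link to the nitrogen, is a smaller alteration than that swap, so no movement beyond the scatter is expected in this assay; the estimated step is a number 1 percentage points lower from compound 2 to compound 3 (within the scatter). Compound 3 is therefore expected to give 123%, within a range from 108% to 136%.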

Compound 3, largest response reached (Emax), in percent of the reference or control that the assay uses: 99%
Compound 3: middle estimate off by 24 percentage points, on the high side, outside the stated range (below it).
By their numbers in this assay, from the lowest: compound 3; then compounds 1 and 2 (each within the scatter of the next).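

In this assay, the group on the saturated chain carbon bound to the amine nitrogen in the ring proves sensitive to a small edit: replacing 1-(trifluoromethyl)cyclopropyl with 1-(trifluoromethyl)cyclobutyl gives a number 25 percentage points lower from compound 2 to compound 3 (beyond the scatter), even though the trifluoromethyl and the link to the nitrogen stay the same. The earlier pair had shown two quite different groups on that nitrogen with values that could not be told apart, yet the comparison with the carbamate-bearing compound now gives a number 24 percentage points lower from compound 1 to compound 3 (beyond the scatter), so a large swap at this nitrogen left the maximal response level while a change in ring size within the group did not. Nothing given here explains why the larger ring lowers the response.

As far as these compounds go, with only these two ring sizes, it remains open whether a 1-(trifluoromethyl)cyclopentyl group would lower the maximal response further or behave differently. A 1-methylcyclobutyl group would show whether the same drop appears when a plain methyl replaces the trifluoromethyl on the four-membered ring.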